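The source may report more compounds than this note shows. Statements on the series, on what has been measured and on what is new or still open speak of the compounds shown alone.

Measured so far:
compound 1 `CC(C)(C)OC(=O)NCc1ccccc1NC(=O)c1cnc2ccccc2c1` gives 15 ug/mL
compound 3 `NC(=O)c1ccccc1NC(=O)c1cnc2ccccc2c1` gives 5 ug/mL
compound 2 `CC(C)(C)OC(=O)NCc1ccccc1NC(=O)c1ccc(-c2ccccc2)cc1` gives only a limit, < 5 ug/mL

In a physicochemical assay for solubility (on this read-out lower numbers stand for lower solubility and higher numbers for higher solubility), compound 1 and compound 3 share one core and differ by a single change, (carbamoyl in place of ((tert-butoxycarbonyl)amino)methyl on an aromatic carbon), and that change gives a 3.0-fold lower number from compound 1 to compound 3 (0.48 log units; beyond the scatter). Compound 2 has a different core; how the two cores differ is not broken down here. In this assay compound 2 shows a limit rather than a number. Compound 4 `NC(=O)c1ccccc1NC(=O)c1ccc(-c2ccccc2)cc1` is to be measured, and it carries the same change on the core of compound 2: carbamoyl in place of ((tert-butoxycarbonyl)amino)methyl on an aromatic carbon. The step is expected to be a step that the limit leaves unreadable from compound 2 to compound 4, in line with a 3.0-fold lower number from compound 1 to compound 3 (0.48 log units; beyond the scatter) and because the limit of < 5 ug/mL in this assay, at which 1 of the 3 values shown sits, leaves little room for a number above the limit. Compound 4 is therefore estimated at 2 ug/mL, most likely reported again only as a limit.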

Compound 4, solubility: 5 ug/mL
Compound 4: the middle estimate sits 2.5-fold (0.40 log units) below what was measured; measured number inside the range.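

In this assay compound 2 gives < 5 ug/mL, which is a limit and not a number. Putting carbamoyl in place of ((tert-butoxycarbonyl)amino)methyl on this core gives a number no lower from compound 2 to compound 4 (the limit leaves the size open), whereas the same change on the other core gives a 3.0-fold lower number from compound 1 to compound 3 (0.48 log units; beyond the scatter), so the drop seen on the core of compound 1 is not repeated as a visible drop here. What this does not show is whether the number truly rises or stays level on the core of compound 2, because the size of the step stays open: the limit of < 5 ug/mL in this assay, at which 1 of the 4 values shown sits.

The compounds shown leave open how an amine or a carboxylic acid at this place would read in this assay. They also leave open which of the two outcomes a third core would follow.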